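Benzotriazole series: halophenyl swap at the carbinol carbon

The source may hold more compounds than are shown below. What is called first, only, known or untested is meant among the compounds shown, and "the series" means these compounds.

Measured compounds:
compound 1, `OC(CCn1nc2c(Br)c(Br)c(Br)c(Br)c2n1)c1cccc(Br)c1`, a functional assay on MCF7 cells (Homo sapiens) for antiproliferative activity, read by MTT assay, with a stated time of 24 h, tested at 50 uM; a higher number here means a weaker effect of the compound at the concentration tested, a lower number a stronger effect: 14%
compound 2, `OC(CCn1nc2c(Br)c(Br)c(Br)c(Br)c2n1)c1cccc(Cl)c1`, this assay: 28%

Compound 2 stands highest of the two numbers in this assay; its nearest neighbour is compound 1, and the step of a number 14 percentage points higher from compound 1 to compound 2 (beyond the scatter) lies beyond the scatter, a modest rise on going from bromo to chloro on the aromatic carbon.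

Compound 3, `OC(CCn1nc2c(Br)c(Br)c(Br)c(Br)c2n1)c1ccc(Br)cc1`, is not yet measured. Its change from compound 2 is 4-bromophenyl in place of 3-chlorophenyl on a saturated chain carbon bound to an oxygen on a saturated carbon and a saturated chain carbon. Two things move at once: the halogen returns from chloro to bromo, and the substituent shifts from 3-chlorophenyl to 4-bromophenyl. Only the first part is covered by a measured step, namely a number 14 percentage points higher from compound 1 to compound 2 (beyond the scatter) run in reverse, which would point to a lower number. Within the data shown here, no measured pair covers the move of the halogen to the other ring position, so that part of the change carries no expectation of its own.

On that basis compound 3 is expected to give a lower number than compound 2, with the step of a number 10 percentage points lower from compound 2 to compound 3 (within the scatter) estimated in this assay. The estimate for compound 3 in this assay is 18%, with a range from 8% to 32%.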

Compound 3, a percentage reported as activity, at one concentration (the size of the read-out at that concentration, not a potency): 10%
Beside the measured number, compound 3's estimate is 8 percentage points above it, within the range that was stated.
By their numbers in this assay, from the lowest: compounds 3 and 1 (each within the scatter of the next); then compound 2.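

In this assay, the step of a number 4 percentage points lower from compound 1 to compound 3 (within the scatter) lies within the scatter, so moving from 3-bromophenyl to 4-bromophenyl on the saturated chain carbon gives no difference that can be read, at least for bromo. Among these compounds, the step of a number 18 percentage points lower from compound 2 to compound 3 (beyond the scatter) lies beyond the scatter, as does a number 14 percentage points higher from compound 1 to compound 2 (beyond the scatter), so across these three compounds the read-out follows the halogen rather than the ring placement, with compound 2, the only chloro member, apart from the two bromo compounds and no compound here going against that. Nothing measured here bears on the cause of this separation.

Open, from the compounds shown here alone, is whether 4-chlorophenyl would sit with the two bromo compounds or with compound 2, which would show whether the chloro result holds at both ring placements or belongs to 3-chlorophenyl alone. Also open is how a plain phenyl, a methoxy group or a carboxylic acid on the ring would read in this assay, since the three compounds shown span only two halogens.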